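A few compounds are considered here, and "the series" means these few. Any claim that something is new, unique, unknown or untested is made for them only; others in the source may bear on it.

Compound 2 `COc1cc(Cl)cc(-c2nn(-c3cccc(NC(=O)Nc4cccc(C(F)(F)F)c4)c3)cc2-c2ccncc2)c1` was tested in a functional assay on SK-MEL-2 cells (Homo sapiens) for inhibition, read by sulforhodamine B assay, with a stated time of 48 h, tested at 1 uM (a higher number here means a weaker effect of the compound at the concentration tested, a lower number a stronger effect), where compound 2 gives 85%. For the measured compounds named here, compound 1 `COc1cc(Cl)cc(-c2nn(-c3cccc(NC(=O)Nc4ccc(Cl)c(C(F)(F)F)c4)c3)cc2-c2ccncc2)c1` is its only measured neighbour; in this assay compound 1 gives 84%, and the two numbers are within the scatter of each other: the step of a number 1 percentage points higher from compound 1 to compound 2 (within the scatter), hydrogen in place of chloro on an aromatic carbon, tells nothing beyond noise. Compound 3 `COc1cc(Cl)cc(-c2nn(-c3cccc(NC(=O)c4cccc(C(F)(F)F)c4)c3)cc2-c2ccncc2)c1` differs from compound 2 by 3-(trifluoromethyl)phenyl in place of (3-(trifluoromethyl)phenyl)amino on a carbonyl carbon. Going by the values given here, no measured step touches this change on the carbonyl carbon, so the only guidance is that the one measured pair shows essentially flat numbers at this concentration. With the hydrogen-bond donor gone, no basis remains for predicting a shift in either direction, and the expectation is a step of about a number 5 percentage points lower from compound 2 to compound 3 (within the scatter) in this assay, within the scatter. Compound 3 is therefore estimated at 80%, with a range from 55% to 100%.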

Compound 3, a percentage reported as activity, at one concentration (the size of the read-out at that concentration, not a potency): 56%
Compound 3: the middle estimate sits 24 percentage points above what was measured, and the stated range covers the measured number.
By their numbers in this assay, from the lowest: compound 3; then compounds 1 and 2 (each within the scatter of the next).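

At the carbonyl carbon, 3-(trifluoromethyl)phenyl in place of (3-(trifluoromethyl)phenyl)amino gives a number 29 percentage points lower from compound 2 to compound 3 (beyond the scatter) in this assay, which means a stronger effect at the concentration tested. For the compounds shown here, the earlier chloro change gave no readable shift, so this is the first sign that the read-out responds to a structural change, and a number 28 percentage points lower from compound 1 to compound 3 (beyond the scatter) points the same way. Nothing available explains the drop, and the loss of the hydrogen-bond donor is only a counted difference between the groups, not a demonstrated cause.

On these data alone, it remains open whether the nitrogen link itself matters, which a methylene group or an oxygen atom in its place could test. Also open, as far as these compounds go, is whether 4-chloro-3-(trifluoromethyl)phenyl on the carbonyl carbon would behave like 3-(trifluoromethyl)phenyl.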